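The source may hold more compounds than are shown below. What is called first, only, known or untested is meant among the compounds shown, and "the series" means these compounds.

Three compounds have been measured in a physicochemical assay on cells (Homo sapiens), with a stated time of 18 h, tested at 10 uM; on this read-out higher numbers stand for a weaker effect at the one concentration tested and lower numbers for a stronger effect:

compound 1 `COc1cc(/C=N/Nc2nc3ccccc3s2)cc(OC)c1O`: 3%
compound 2 `COc1cc(/C=N/N(C)c2nc3ccccc3s2)cc(OC)c1O`: 3%
compound 3 `COc1cc(/C=N/N2C(=O)CSC2=S)cc(OC)c1O`: 5%

Compound 1 stands level with compound 2 at the digits shown; together they hold the lowest two numbers of the three, and compound 3 lies within the scatter of both. Among the measured compounds shown here, the only measured step, no change at the digits printed from compound 1 to compound 2 (within the scatter), shows that adding a methyl to the shared core of compound 1 left the read-out unchanged. Compound 4 `COc1cc(/C=N/Nc2nc3ccccc3s2)cc(OC)c1OC` differs from compound 1 by methyl in place of hydrogen on an oxygen on an aromatic ring. The methyl step from compound 1 to compound 2 is the nearest guide, so the expected step of a number 3 percentage points higher from compound 1 to compound 4 (within the scatter) is none beyond the scatter. Compound 4 is therefore estimated at 6%, ranging from 0% to 20%.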

Compound 4, a percentage reported as activity, at one concentration (the size of the read-out at that concentration, not a potency): 14%
Compound 4: middle estimate off by 8 percentage points, on the low side, and the stated range covers the measured number.
By their numbers in this assay, from the lowest: compounds 1, 2, 3 and 4 (each within the scatter of the next, the first and the last beyond it).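

In this assay, changing hydroxy to methoxy gives a number 11 percentage points higher from compound 1 to compound 4 (beyond the scatter) and so marks the weaker effect at this position. A methyl on this oxygen therefore matters more than the methyl on nitrogen, which gave no change at the digits printed from compound 1 to compound 2 (within the scatter) and stayed level. No measurement at hand explains this difference.

Still open, going by these compounds, is whether a longer chain on this oxygen, such as ethyl, would weaken the effect further. An amine in place of the hydroxy is also untested in the compounds shown here.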